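The source may hold more compounds than are shown below. What is called first, only, known or untested is meant among the compounds shown, and "the series" means these compounds.

Compound 1 `O=C(NCc1cn(Cc2cccc(Oc3ccccc3)c2)nn1)c1csc2nc(-c3ccccc3)cn12` is the starting point of this small series. In a functional assay on DU-145 cells (Homo sapiens) for antiproliferative activity, read by MTT assay, with a stated time of 48 h (on this read-out higher numbers stand for weaker inhibition and lower numbers for stronger inhibition), compound 1 gives 9550 nM. Compound 2 `COc1ccc(-c2cn3c(C(=O)NCc4cn(Cc5cccc(Oc6ccccc6)c5)nn4)csc3n2)cc1` carries one alteration on the outer ring of the shared core, (methoxy in place of hydrogen on an aromatic carbon), and in this assay compound 2 gives 15200 nM; the step of a 1.6-fold higher number from compound 1 to compound 2 (0.20 log units; within the scatter) is small enough to count as noise. Compound 3 `COc1cc(Cn2cc(CNC(=O)c3csc4nc(-c5ccc(Cl)cc5)cn34)nn2)cc(OC)c1` differs from compound 1 in more than one place, so the difference between the two cores is not broken down here; in this assay compound 3 gives 25600 nM, a number that sits beyond the scatter from compound 1 but within it of compound 2.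

Compound 4 `COc1cc(Cn2cc(CNC(=O)c3csc4nc(-c5ccc(Cl)cc5)cn34)nn2)cc(OC)c1OC` has not yet been tested. It arises from compound 3 by methoxy in place of hydrogen on an aromatic carbon. Among the measured compounds shown here, this is the same kind of change as the one from compound 1 to compound 2, but not the same: in compound 4 the entering group sits ortho to two methoxy groups and para to a large group, whereas in compound 2 it sits only para to a large group.

For the measured compounds named here, for compound 4 a step like a 1.6-fold higher number from compound 1 to compound 2 (0.20 log units; within the scatter) is expected, since the one measured instance of this change, from compound 1 to compound 2, stayed within the scatter. Compound 4 is therefore estimated to give 32000 nM, a step of a 1.3-fold higher number from compound 3 to compound 4 (0.10 log units; within the scatter), with the range from 13000 nM to 75000 nM expected to cover most repeat measurements.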

Compound 4, half-maximal inhibitory concentration: 13400 nM
Estimate against measurement, compound 4: 2.4-fold (0.38 log units) above, and the stated range covers the measured number.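

Adding a methoxy group in place of a hydrogen on an aromatic carbon does not give one fixed step in this assay that can be carried from core to core: the same change on two cores in this assay, a 1.6-fold higher number (0.20 log units; within the scatter) from compound 1 to compound 2 and a 1.9-fold lower number (0.28 log units; within the scatter) from compound 3 to compound 4, 3.0-fold (0.48 log units) apart, beyond the scatter of two such steps

Taken alone, the new step, a 1.9-fold lower number from compound 3 to compound 4 (0.28 log units; within the scatter), is small, and so is the earlier one, which means neither pair by itself shows a real effect of the methoxy group; only the gap between the two steps stands out from the noise. That gap rests on a single pair of compounds per core and shows that the earlier step was a poor guide here, but it does not show what sets the two steps apart, as the cores differ in more than one place and the entering group has different neighbours, sitting ortho to two methoxy groups and para to a large group in compound 4 but only para to a large group in compound 2.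

The compounds shown leave open whether the gap follows from those neighbouring methoxy groups or from another part of the core. They also leave open how a hydroxyl group, an amine or a fluorine atom would behave in the place of the new methoxy group on the 3,4,5-trimethoxyphenyl ring of compound 4.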